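The source may report more compounds than this note shows. Statements on the series, on what has been measured and on what is new or still open speak of the compounds shown alone.

The study compares a small set of amides built on a shared core and read for their ability to block a calcium signal. Compound 1 `O=C(Nc1ccc(Br)cn1)c1csc(Cc2c(Cl)cccc2Cl)n1` opens the series. In an assay on CHO cells, read by calcium flux (a lower number here means a stronger inhibitor, a higher number a weaker inhibitor), compound 1 gives only a limit, > 4000 nM, and no actual number. Compound 2 `O=C(Nc1ccc(C(F)(F)F)cc1)c1cnc(Cc2c(Cl)cccc2Cl)s1` differs from compound 1 in its core and in its aryl amide, which now carries a trifluoromethyl group. In this assay, going by the values given here, compound 2 gives 1780 nM, the single measured number among the two results. The other result, that of compound 1, is a limit (the limit of > 4000 nM in this assay, at which 1 of the 2 values shown sits). Among the compounds with values here, no pair of measured compounds differs in one place only, so no measured step between them can be drawn.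

Compound 3 `Cc1nc(Cc2c(Cl)cccc2Cl)sc1C(=O)Nc1ccc(C(F)(F)F)cc1` has not yet been measured. It differs from compound 2 by methyl in place of hydrogen on an aromatic carbon. Within the data shown here, with no measured step to lean on, the change is expected to move the result only a little in this assay, and a 1.2-fold lower number from compound 2 to compound 3 (0.07 log units; within the scatter) is estimated to stay within the usual scatter of the measurement. In this assay compound 3 is therefore expected to give about 1500 nM, in a range from 500 nM to 4500 nM.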

Compound 3, half-maximal inhibitory concentration: > 4000 nM
Compound 3 gave a limit, no number; the forecaster's own chance of this, stated with the estimate: 20%; middle value at least 2.6-fold (0.42 log units) away from the limit.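

In this assay, going by these compounds alone, methyl in place of hydrogen on an aromatic carbon gives an at least 2.2-fold higher number from compound 2 to compound 3 (0.35 log units; beyond the scatter), and this is the first step that changes one place only. It shows that this position, on the five-membered aromatic ring next to the ring nitrogen and next to the ring atom that bears a large group, is not indifferent to change: a single added carbon is enough to move the result beyond the scatter, towards weaker inhibition. Compound 3 gives a limit, > 4000 nM, and no actual number, so the step fixes only a direction and a minimum size, and the limit now holds most of the series: the limit of > 4000 nM in this assay, at which 2 of the 3 values shown sit.

The compounds shown leave open whether any other group at this position, such as a fluorine atom, a hydroxymethyl group or an amine, would retain the inhibition seen for compound 2 at 1780 nM. They also leave open whether the same change would weaken inhibition to a similar extent with an aryl amide other than the one carrying trifluoromethyl.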